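Aromatic substituent exchange: compound 3 to compound 4

The compounds below may be only part of what the source reports. "The series", "measured", "known", "first", "only" and "open" are said of these compounds alone.

Measured compounds, each in a functional assay on T47D cells (Homo sapiens) for inhibition, read by sulforhodamine B assay, with a stated time of 48 h; a lower number here means a stronger inhibitor of growth, a higher number a weaker inhibitor of growth:
compound 1 `COC(=O)[C@@]1(C)CC[C@@H]2C3=C1CC[C@@H](C)[C@]3(C)C[C@@H]1c3cc(Br)ccc3N[C@H]21`; compound 1 gives 31000 nM
compound 2 `COC(=O)[C@@]1(C)CC[C@@H]2C3=C1CC[C@@H](C)[C@]3(C)Cc1c2[nH]c2ccccc12`; compound 2 gives 3400 nM
compound 3 `COC(=O)[C@@]1(C)CC[C@@H]2C3=C1CC[C@@H](C)[C@]3(C)Cc1c2[nH]c2ccc(C)cc12`; compound 3 gives 16000 nM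

Compound 3 holds the second highest of the three numbers. Its value and that of compound 1 lie within the usual scatter of each other, so no order between them is read. For the measured compounds named here, compound 2 is separated from it by a 4.7-fold higher number from compound 2 to compound 3 (0.67 log units; beyond the scatter), the only single-point change measured in the set: methyl in place of hydrogen on an aromatic carbon.

Compound 4 `COC(=O)[C@@]1(C)CC[C@@H]2C3=C1CC[C@@H](C)[C@]3(C)Cc1c2[nH]c2ccc(OC)cc12` differs from compound 3 by methoxy in place of methyl on an aromatic carbon. Going by the values given here, no measured pair exchanges methyl for methoxy, so this step has no direct precedent. Among the compounds with values here, the one step measured at that aromatic carbon, a 4.7-fold higher number from compound 2 to compound 3 (0.67 log units; beyond the scatter), was modest in size; putting a methoxy there in place of the methyl is taken as a change of similar scale, and its direction is not fixed by any measured step. A step within or close to the scatter is therefore expected in this assay.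

Compound 4 is estimated at 14000 nM, with a range of 5000 nM to 40000 nM. This estimate corresponds to a 1.1-fold lower number from compound 3 to compound 4 (0.06 log units; within the scatter).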

Compound 4, concentration for 50% growth inhibition: 6500 nM
The estimate for compound 4 lay 2.2-fold (0.33 log units) above the measured number, within the range that was stated.
By their numbers in this assay, from the lowest: compounds 2 and 4 (each within the scatter of the next); then compounds 3 and 1 (each within the scatter of the next).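

In this assay, for the compounds shown here, the step of a 2.5-fold lower number from compound 3 to compound 4 (0.39 log units; beyond the scatter) is the first exchange of one substituent for another at this aromatic carbon, and it shows that the reading there depends on which group is present, not merely on hydrogen having been replaced. Of the two groups now seen on this carbon, only methyl is separated from hydrogen beyond the scatter, by a 4.7-fold higher number from compound 2 to compound 3 (0.67 log units; beyond the scatter); methoxy stays within it, by a 1.9-fold higher number from compound 2 to compound 4 (0.28 log units; within the scatter), so compound 2 and compound 4 are not put in any order. Nothing available here accounts for this difference between methyl and methoxy.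

As far as these compounds go, with only hydrogen, methyl and methoxy to compare at this carbon, it remains open whether a hydroxyl, an amine, a carboxylic acid or a longer chain such as ethoxy would read like hydrogen and methoxy or like methyl. It is also open whether methoxy would give a similar reading on another carbon of this six-membered aromatic ring, as all the single-point steps shown concern this one carbon.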